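The source may report more compounds than this note shows. Statements on the series, on what has been measured and on what is new or still open speak of the compounds shown alone.

Measured in a functional assay on RAW264.7 cells (Mus musculus) for inhibition, read by Griess assay, with stated times of 3 h and 24 h (on this read-out higher numbers stand for weaker inhibition and lower numbers for stronger inhibition), as follows
- compound 1 `C=C1CCC2[C@](C)(CO)[C@H](O)CC[C@@]2(C)[C@@H]1CCn1ccnc1` gives > 50000 nM (a limit)
- compound 2 `C=C1CCC2[C@](C)(CO)[C@H](O)CC[C@@]2(C)[C@@H]1CCOc1ccc(Oc2ccccc2)cc1` gives 12800 nM (a number)

Compound 1 sits at the limit of > 50000 nM in this assay, at which 1 of the 2 values shown sits, and so has no number. Compound 3 `C=C1CCC2[C@](C)(CO)[C@H](O)CC[C@@]2(C)[C@@H]1CCOc1ccccc1O` is not yet measured. It differs from compound 1 by 2-hydroxyphenoxy in place of 1H-imidazol-1-yl on a saturated chain carbon, two bonds along the chain from a saturated ring carbon. Going by the values given here, no measured pair differing in one place is available to set the size of this change. Compound 2 also holds an aromatic ring joined through oxygen on that chain and gives 12800 nM in this assay so the change is expected to run towards stronger inhibition. The expected at least 2.5-fold lower number from compound 1 to compound 3 (0.39 log units; beyond the scatter) has an open size, since its starting point is a limit. For compound 3 the estimated value is 20000 nM (expected range 8000 nM to 40000 nM).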

Compound 3, half-maximal inhibitory concentration: 47700 nM
Estimate against measurement, compound 3: 2.4-fold (0.38 log units) below; measured number above the stated range.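

In this assay, going by these compounds alone, compound 3 gives 47700 nM as a number, the first reading for 2-hydroxyphenoxy on a saturated chain carbon, two bonds along the chain from a saturated ring carbon. Putting that group in place of 1H-imidazol-1-yl reads as an at least 1.0-fold lower number from compound 1 to compound 3 (0.02 log units; that floor lies within the scatter) and so establishes no change beyond the scatter. On these data alone, the true size of the step stays open because compound 1 has only a limit: the limit of > 50000 nM in this assay, at which 1 of the 3 values shown sits.

The compounds shown leave open what a plain phenoxy group would give on this chain carbon, so the share of the hydroxyl within 2-hydroxyphenoxy cannot be read. As far as these compounds go, an amine, a carboxylic acid or a longer chain at the same place also remains open, as does any effect of these groups on the shared core's value in this read-out.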